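A few compounds are considered here, and "the series" means these few. Any claim that something is new, unique, unknown or untested is made for them only; others in the source may bear on it.

Measured compounds:
compound 1, `COc1nc2ccc(Br)cc2cc1C(c1ccccc1)n1cc(-c2ccccc2)nn1`, 13.9%
compound 2, `CCCCc1cn(C(c2ccccc2)c2cc3cc(Br)ccc3nc2OC)nn1`, -2.87%
compound 3, `COc1nc2ccc(Br)cc2cc1C(c1ccccc1)n1cc(-c2ccccc2F)nn1`, 14.1%

These three share one core and differ only in the group carried on the triazole ring. In an ADME assay on HeLa cells (Homo sapiens) for cytotoxicity, read by sulforhodamine B assay, with a stated time of 48 h, tested at 10 uM (on this read-out lower numbers stand for less inhibition and higher numbers for more inhibition at the one concentration tested (going by the name of the read-out)), compound 2 stands lowest of the three numbers: the step of a number 16.8 percentage points lower from compound 1 to compound 2 (beyond the scatter) and the step of a number 17 percentage points higher from compound 2 to compound 3 (beyond the scatter) both lie beyond the scatter, while a number 0.2 percentage points higher from compound 1 to compound 3 (within the scatter) stays within it. So the butyl chain in compound 2 goes with less inhibition than either aryl group.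

Compound 4, `COc1nc2ccc(Br)cc2cc1C(c1ccccc1)n1cc(CCO)nn1`, keeps the chain but shortens it and caps it with an alcohol: hydroxy in place of ethyl on a saturated chain carbon, two bonds along the chain from an aromatic carbon. Going by the values given here, no measured step involves a hydroxy group, so the two steps that bear on it do so only loosely; they show that exchanging the whole group on this ring moved this assay by a modest amount, and that a chain gave the lowest number seen. Since compound 4 still carries a chain rather than a ring at this place, the number is expected to stay near that of compound 2, with room for a shift either way; the step of a number 5.9 percentage points higher from compound 2 to compound 4 (within the scatter) is therefore expected to fall within the scatter. For compound 4 the estimate in this assay is 3%, with a range from -12% to 18%.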

Compound 4, a percentage reported as inhibition, at one concentration (the size of the read-out at that concentration, not a potency): 0.85%
Estimate against measurement, compound 4: 2.2 percentage points above; measured number inside the range.
By their numbers in this assay, from the lowest: compounds 2 and 4 (each within the scatter of the next); then compounds 1 and 3 (each within the scatter of the next).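

In this assay, placing a hydroxy group on the chain, which turns butyl into 2-hydroxyethyl, gives a number 3.7 percentage points higher from compound 2 to compound 4 (within the scatter), so the hydrogen-bond donor and acceptor that this group adds at the end of the chain produce no change this read-out can separate from the scatter. The second chain also stays apart from both aryl groups, with a number 13.1 percentage points lower from compound 1 to compound 4 (beyond the scatter) and a number 13.3 percentage points lower from compound 3 to compound 4 (beyond the scatter), so the pattern seen with butyl now rests on two different chains: among these four compounds, the two chains give lower numbers than the two aryl groups, and no compound goes against this. Nothing available here explains why chains and aryl groups differ in this way.

From the compounds shown here alone, it remains open whether a chain ending in an amine or a carboxylic acid would stay with compound 2 and compound 4 or move toward compound 1 and compound 3. A cyclohexyl group on the triazole ring would help show whether the higher numbers go with any ring at this place or only with an aromatic one.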